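The source may report more compounds than this note shows. Statements on the series, on what has been measured and on what is new or still open speak of the compounds shown alone.

Among the compounds with values here, compound 1 `CCn1c(=O)[nH]c2ccc(OCCOc3ccc(OC)cc3)cc21` is the only compound in this set that comes with a numerical result. In an assay on cells for inhibition of Amine oxidase [flavin-containing] B (Homo sapiens), read by fluorescence, with stated times of 30 min and 15 min, tested at 1 uM (on this read-out higher numbers stand for more inhibition at the one concentration tested (going by the name of the read-out) and lower numbers for less inhibition), compound 1 gives 13.9%, a small effect at the single concentration tested. Compound 2 `Cn1c(=O)[nH]c2cc(OCc3ccccc3)ccc21` was also examined, and in this assay compound 2 was reported as "not active" (no number reported), with no number attached. Compound 2 differs from compound 1 in more than one place, so the two do not form a single-change pair, and nothing about the size of any step can be read from them together. Compound 3 `CCn1c(=O)[nH]c2ccc(OCCOc3ccc(Cl)cc3)cc21` has not been measured. It differs from compound 1 in one place: chloro in place of methoxy on an aromatic carbon. Within the data shown here, no pair of measured compounds shows what a change of this kind does here, so there is no measured step to lean on. The step of a number 2.1 percentage points higher from compound 1 to compound 3 (within the scatter) is therefore expected to stay within the scatter of the measurement, with no clear direction. For compound 3 the expected result in this assay is 16%, in the range from 2% to 32%.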

Compound 3, a percentage reported as inhibition, at one concentration (the size of the read-out at that concentration, not a potency): 7.24%
Beside the measured number, compound 3's estimate is 8.8 percentage points above it, and the stated range covers the measured number.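

Within the data shown here, this is the first pair in the set that differs in one place, so it gives the first measured step for this position, on a six-membered aromatic ring of carbon only, para to a large group. In this assay, replacing methoxy with chloro gives a number 6.7 percentage points lower from compound 1 to compound 3 (within the scatter), so the 4-methoxyphenyl and 4-chlorophenyl forms cannot be told apart at the one concentration tested, and the oxygen of the methoxy, with its hydrogen-bond acceptor, is not shown to be needed for the small inhibition seen. No supporting measurement bears on this result.

What the compounds shown leave open is whether any group at this position can move the read-out clearly beyond the scatter, and an amine, a carboxylic acid or a longer chain there would put that to the test. They also leave open whether the same exchange would give a step of similar size on a compound with stronger inhibition, where a real difference would be easier to see against the scatter.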